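The compounds below may be only part of what the source reports. "The series", "measured", "known", "first", "only" and "open" are said of these compounds alone.

Measured so far in a functional assay on MDA-MB-435 cells (Homo sapiens) for cytotoxicity, read by MTT assay, with a stated time of 72 h; a higher number here means a weaker inhibitor, a lower number a stronger inhibitor:
- compound 1 `NCCNc1c(C(=O)NCc2ccc(F)cc2)nc(Br)c2cccnc12`: 12000 nM
- compound 2 `O=C(NCc1ccc(F)cc1)c1nc(Br)c2cccnc2c1N1CCNCC1`: 8000 nM

Compound 2 has only compound 1 for comparison, and the two numbers lie within the scatter of each other. Compound 3 `CNCCCNc1c(C(=O)NCc2ccc(F)cc2)nc(Br)c2cccnc12` has not yet been measured. It carries (3-(methylamino)propyl)amino in place of piperazin-1-yl on an aromatic carbon.

Within the data shown here, one measured step bears on this change: a 1.5-fold lower number from compound 1 to compound 2 (0.18 log units; within the scatter). That step exchanges an open chain and piperazin-1-yl on the same aromatic carbon, the reverse sense of the change to compound 3, and it stays within the scatter. Its chain is (2-aminoethyl)amino, however, so it is only a partial guide to the chain in compound 3. No step beyond the scatter is therefore expected in this assay, and neither direction is favoured. The estimated step is a 1.3-fold higher number from compound 2 to compound 3 (0.10 log units; within the scatter). The expected value for compound 3 is 10000 nM, with an estimated range from 3500 nM to 28000 nM.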

Compound 3, half-maximal inhibitory concentration: 11000 nM
Estimate against measurement, compound 3: 1.1-fold (0.04 log units) below, within the range that was stated.
By their numbers in this assay, from the lowest: compounds 2, 3 and 1 (each within the scatter of the next).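

In this assay, replacing piperazin-1-yl with (3-(methylamino)propyl)amino on this aromatic carbon, para to a bromo group, gives a 1.4-fold higher number from compound 2 to compound 3 (0.14 log units; within the scatter), so removing the ring while keeping the heavy-atom count gives no readable separation here, despite the difference in hydrogen-bond donors. The two open chains also stay together, with (methylamino)methyl in place of amino on the saturated chain carbon giving a 1.1-fold lower number from compound 1 to compound 3 (0.04 log units; within the scatter), which extends the earlier comparison between a ring and a chain to a comparison between two chains and shows that this assay does not separate any of the three side groups at this position. No supporting measurement is available to explain this shared behaviour.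

As far as these compounds go, it remains open whether a carboxylic acid, a hydroxyl group or a much longer chain on this aromatic carbon would move the number beyond the scatter. The compounds shown also leave open whether these side groups would stay equally hard to separate if the bromo group were replaced by a chloro group or a hydrogen atom.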